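This account rests on a few compounds, and the source may have more. Where it says the series, first, only, none or still open, it means among the compounds named here.

Measured in a functional assay on HT-29 cells (Homo sapiens) for inhibition, read by sulforhodamine B assay, with a stated time of 72 h; on this read-out lower numbers stand for stronger inhibition and higher numbers for weaker inhibition:
Compound 1 `COc1cc2c(Nc3ccc(F)c(Cl)c3)ncnc2cc1OCCOCCn1ccnc1[N+](=O)[O-]` gives 5520 nM
Compound 2 `C#Cc1cccc(Nc2ncnc3cc(OCCCCn4ccnc4[N+](=O)[O-])c(OC)cc23)c1` gives 590 nM
Compound 3 `COc1cc2c(Nc3ccc(OCc4cccc(F)c4)c(Cl)c3)ncnc2cc1OCCCCCn1ccnc1[N+](=O)[O-]` gives 5040 nM

Compound 3 stands at the upper end of these numbers, within the scatter of compound 1, while compound 2 has a clearly lower number, beyond the scatter. The next compound to be tested is compound 4 `COc1cc2c(Nc3ccc(OCc4cccc(F)c4)c(Cl)c3)ncnc2cc1OCCOCCn1ccnc1[N+](=O)[O-]`, in which 2-(2-nitro-1H-imidazol-1-yl)ethoxy takes the place of 3-(2-nitro-1H-imidazol-1-yl)propyl on a saturated chain carbon: 2-(2-nitro-1H-imidazol-1-yl)ethoxy in place of 3-(2-nitro-1H-imidazol-1-yl)propyl on a saturated chain carbon, two bonds along the chain from an oxygen on an aromatic ring. For the measured compounds named here, no measured pair here differs in one place only, so no direct step guides the expectation. The entering chain also occurs in compound 1 (5520 nM), whose value lies within the scatter of that of compound 3 (5040 nM). In this assay no change beyond the scatter is therefore expected, and the estimated step is small: a 1.0-fold lower number from compound 3 to compound 4 (0.00 log units; within the scatter) in either direction. For compound 4 the estimate is 5000 nM, with an expected range from 2000 nM to 12000 nM.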

Compound 4, half-maximal inhibitory concentration: 2590 nM
For compound 4 the middle estimate is 1.9-fold (0.29 log units) above the measured one; the measured number falls inside the stated range.
By their numbers in this assay, from the lowest: compound 2; then compounds 4, 3 and 1 (each within the scatter of the next, the first and the last beyond it).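

In this assay, for the compounds shown here, the first comparisons of compounds differing in one place become readable. 2-(2-nitro-1H-imidazol-1-yl)ethoxy in place of 3-(2-nitro-1H-imidazol-1-yl)propyl on this saturated chain carbon gives a 1.9-fold lower number from compound 3 to compound 4 (0.29 log units; within the scatter) and so does not separate from the scatter, whereas (3-fluorobenzyl)oxy in place of fluoro on an aromatic carbon gives a 2.1-fold lower number from compound 1 to compound 4 (0.33 log units; beyond the scatter) and this modest step is the only one of the two to pass it. No evidence is available that would account for either step.

From the compounds shown here alone, each change is read only once, on a single background, so it remains open whether either step would recur on another one. Going by these compounds, it also remains open whether a longer chain, or an amine in place of the 2-nitro-1H-imidazol-1-yl end of the chain, would shift the number beyond the scatter.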